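Swapping the chloropyridinyl isomer on the amide carbonyl

The source may report more compounds than this note shows. Statements on the series, on what has been measured and on what is new or still open speak of the compounds shown alone.

compound 1: `O=C(O)/C=C/C(=O)Nc1cccc(-c2nc3ccccc3s2)c1`, > 25000 nM
compound 2: `CC(Cl)C(=O)Nc1cccc(-c2nc3ccccc3s2)c1`, > 25000 nM
compound 3: `O=C(Nc1cccc(-c2nc3ccccc3s2)c1)c1cnccc1Cl`, > 25000 nM

Compound 1, compound 2 and compound 3 share one core and differ only in the group attached to the carbonyl carbon of the amide. In an ADME assay on HepG2 cells (Homo sapiens) for inhibition, with a stated time of 72 h (a lower number here means that less compound is needed, a higher number that more compound is needed for the effect), compound 1 gives > 25000 nM, which is a limit of the assay and not a number. Compound 2 likewise gives > 25000 nM, a limit. Compound 3 gives > 25000 nM, again a limit. The steps a step that the two limits leave unreadable from compound 1 to compound 2, a step that the two limits leave unreadable from compound 1 to compound 3 and a step that the two limits leave unreadable from compound 2 to compound 3 therefore have no readable size; every value shown rests at the limit of > 25000 nM in this assay, at which 3 of the 3 values shown sit. Compound 3 thus stands at the limit, indistinguishable from the other two on the numbers available.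

Compound 4 `O=C(Nc1cccc(-c2nc3ccccc3s2)c1)c1ccncc1Cl` differs from compound 3 by 3-chloropyridin-4-yl in place of 4-chloropyridin-3-yl on a carbonyl carbon. None of the three measured steps that exchange the group on this carbonyl carbon produced a size the assay could resolve, so nothing points to a shift in either direction. The step from compound 3 to compound 4 is expected to be a step that the limit leaves unreadable from compound 3 to compound 4, with no change beyond the scatter foreseen. Compound 4 is estimated at 40000 nM, within 15000 nM to 120000 nM, and most likely only a limit would again be reported.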

Compound 4, half-maximal effective concentration: > 25000 nM
Compound 4: a limit, no number; the forecaster's own chance of this, stated with the estimate: 85%; the middle value does not contradict the limit.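

In this assay compound 4 gives > 25000 nM as a limit and not a number, so its steps from compound 1, compound 2 and compound 3 cannot be read. All the results shown rest at the same point: the limit of > 25000 nM in this assay, at which 4 of the 4 values shown sit. The compounds shown leave open whether any group on this carbonyl carbon would give a readable value in this assay at all.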